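The source may report more compounds than this note shows. Statements on the series, on what has been measured and on what is new or still open speak of the compounds shown alone.

Measured compounds:
compound 1 `CCCS(=O)(=O)c1cccc(C#Cc2cc(Cl)ccc2OCC(=O)O)c1` — 9 nM
compound 2 `COCc1ccc(F)c(C#Cc2cc(Cl)ccc2OCC(=O)O)c1` — 72 nM
compound 3 `CC1(C)C(=O)c2ccc(C#Cc3cc(Cl)ccc3OCC(=O)O)cc2S1(=O)=O` — 31 nM

Three analogues sharing one core have been tested in an assay on CHO cells for displacement of a labelled ligand from prostaglandin D2 receptor 2 (Homo sapiens), read by scintillation counting; on this read-out higher numbers stand for weaker inhibition and lower numbers for stronger inhibition. Compound 1 `CCCS(=O)(=O)c1cccc(C#Cc2cc(Cl)ccc2OCC(=O)O)c1` stands lowest of the three numbers, giving 9 nM in this assay. Compound 3 `CC1(C)C(=O)c2ccc(C#Cc3cc(Cl)ccc3OCC(=O)O)cc2S1(=O)=O` is nearest to it with 31 nM, a gap that lies beyond the usual scatter, and compound 2 `COCc1ccc(F)c(C#Cc2cc(Cl)ccc2OCC(=O)O)c1` is furthest with 72 nM, also beyond the scatter. All three carry a substituted aromatic ring on the alkyne side of the core; none of them shows that ring bare.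

Compound 4 `O=C(O)COc1ccc(Cl)cc1C#Cc1ccccc1` is the unmeasured member. It differs from compound 1 in one place: hydrogen in place of propylsulfonyl on an aromatic carbon. The propylsulfonyl of compound 1 is thus removed and nothing takes its place on that aromatic carbon.

Among the measured compounds shown here, no step between measured compounds touches this position, so the size of the change is not known from the measured set. Because compound 1 gives 9 nM with the propylsulfonyl present, and the other substituted analogues give weaker numbers, the account expects compound 4 to move toward weaker inhibition, with the estimated step of a 17-fold higher number from compound 1 to compound 4 (1.22 log units; beyond the scatter) beyond the scatter. Compound 4 is expected to give about 150 nM in this assay, within a range of 40 nM to 600 nM.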

Compound 4, inhibition constant: 108 nM
Beside the measured number, compound 4's estimate is 1.4-fold (0.14 log units) above it; low and high end bracket the measured number.
By their numbers in this assay, from the lowest: compound 1; then compound 3; then compounds 2 and 4 (each within the scatter of the next).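

In this assay, hydrogen in place of propylsulfonyl on an aromatic carbon brings a 12-fold higher number from compound 1 to compound 4 (1.08 log units; beyond the scatter) and is a large step, the first one that can be read at this position. It shows that the low number of compound 1 depends on the propylsulfonyl on this carbon, and that the bare ring still gives a finite number, with compound 4 at 108 nM in this assay as the reference against which any group placed here can now be judged. The measurements shown offer nothing that accounts for the size of this step.

Because the whole propylsulfonyl leaves at once, the compounds shown do not tell whether the step belongs to the sulfonyl or to the propyl chain, and a methylsulfonyl, a butylsulfonyl, a sulfonamide or a plain propyl chain on the same aromatic carbon would be needed to separate the two. They also leave open how an amine or a carboxylic acid at this place would compare with hydrogen, and whether a step of this size would recur on a core that carries a different substituent elsewhere on the ring.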